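The compounds below may be only part of what the source reports. "The series", "measured", "known", "first", "only" and "open" are said of these compounds alone.

In a functional assay on the whole organism (strain Sprague-Dawley) for inhibition, with Rattus norvegicus as the target (a higher number here means that more compound is needed for the effect, a lower number that less compound is needed), compound 1 `COc1ccc2ncc(-c3nn[nH]n3)cc2c1` gives 10 mg/kg. Compound 2 `COc1ccc2ncc(C(=O)O)cc2c1` reaches only a limit, > 5 mg/kg, in this assay. Compound 3 `O=C(O)c1cnc2cc(C(F)(F)F)ccc2c1` likewise stops at a limit of > 25 mg/kg in this assay. The difference between the cores of compound 2 and compound 3 is not broken down here. From compound 2 to compound 1 the change is 2H-tetrazol-5-yl in place of carboxy on an aromatic carbon. The step that the limit leaves unreadable from compound 2 to compound 1 stays unreadable. This is so because compound 2 sits at the limit of > 5 mg/kg in this assay, at which 1 of the 3 values shown sits. Compound 4 `FC(F)(F)c1ccc2cc(-c3nn[nH]n3)cnc2c1` carries the same change on the core of compound 3, (2H-tetrazol-5-yl in place of carboxy on an aromatic carbon). Compound 3 stands at the limit of > 25 mg/kg in this assay, at which 1 of the 3 values shown sits, so that side gives no anchor either. For compound 4 the estimated step is a number no higher from compound 3 to compound 4 (the limit leaves the size open), resting on compound 1 showing an effect at 10 mg/kg with the same group. Compound 4 is expected to give about 25 mg/kg, between 10 mg/kg and 50 mg/kg.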

Compound 4, minimum effective dose: < 10 mg/kg
Compound 4: only a limit was reported (the forecaster's own chance of this, stated with the estimate: 40%); at least 2.5-fold (0.39 log units) between middle value and limit.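

On the core of compound 3, 2H-tetrazol-5-yl in place of carboxy on an aromatic carbon gives, in this assay, an at least 2.5-fold lower number from compound 3 to compound 4 (0.39 log units; beyond the scatter). On the core of compound 1 the same change cannot be read, since compound 2 reaches only a limit, > 5 mg/kg. The change is therefore shown to lower the number on one core only, and even there the true size of the step stays open, as compound 3 and compound 4 both stand at limits.

The compounds shown leave open whether an amide or a nitrile on the same aromatic carbon would act as 2H-tetrazol-5-yl does. They also leave open whether the step would hold on a core carrying a chlorine atom instead of trifluoromethyl or methoxy.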